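The source may hold more compounds than are shown below. What is called first, only, known or untested is meant among the compounds shown, and "the series" means these compounds.

Measured so far:
Compound 1, `CCC1C(=O)N(C)c2cnc(Nc3ccc(S(N)(=O)=O)cc3)nc2N1C`: 479 nM
Compound 2, `CCc1ccccc1C1C(=O)N(C)c2cnc(Nc3ccc(S(N)(=O)=O)cc3)nc2N1C`: 51 nM

Both numbers come from an assay on Sf9 cells for inhibition of serine/threonine-protein kinase 4 (Homo sapiens), read by luminescence and ADP-Glo, with a stated time of 1 h, in the presence of a further agent that is not named here; a lower number here means a stronger inhibitor, a higher number a weaker inhibitor. Compound 2 stands as the lower of the two, the step of a 9.4-fold lower number from compound 1 to compound 2 (0.97 log units; beyond the scatter) setting it apart from compound 1. Compound 3, `Cc1c(F)cccc1C1C(=O)N(C)c2cnc(Nc3ccc(S(N)(=O)=O)cc3)nc2N1C`, is the next one to be measured. Its change is 3-fluoro-2-methylphenyl in place of 2-ethylphenyl on a saturated ring carbon. For the measured compounds named here, the one measured step swaps a plain chain for a ring, so it only shows that an aromatic group on that carbon helps; no step here compares one such ring with another. For compound 3 the expected step is a 1.1-fold lower number from compound 2 to compound 3 (0.05 log units; within the scatter), not beyond the scatter. The estimate for compound 3 is 45 nM, within 15 nM to 150 nM.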

Compound 3, half-maximal inhibitory concentration: 419 nM
Compound 3: middle estimate off by 9.3-fold (0.97 log units), on the low side, and the stated range ends below it.
By their numbers in this assay, from the lowest: compound 2; then compounds 3 and 1 (each within the scatter of the next).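

Replacing 2-ethylphenyl with 3-fluoro-2-methylphenyl on this saturated ring carbon gives an 8.2-fold higher number from compound 2 to compound 3 (0.91 log units; beyond the scatter), even though both groups hold one six-membered aromatic ring and the same count of heavy atoms. An aromatic ring here therefore does not secure strong inhibition by itself, and the exact groups on that ring matter: the comparison with the plain ethyl compound is a 1.1-fold lower number from compound 1 to compound 3 (0.06 log units; within the scatter). No evidence on hand accounts for this result.

Two things changed together on the ring, so the effects of the fluorine and of methyl in place of ethyl cannot be separated. As far as these compounds go, how a plain phenyl group on this carbon would compare also stays open.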